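The source may report more compounds than this note shows. Statements on the series, on what has been measured and on what is new or still open speak of the compounds shown alone.

Three analogues built on one shared core have been measured in an assay on isolated protein for inhibition of long-chain fatty acid transport protein 1 (Homo sapiens); a higher number here means a weaker inhibitor, a lower number a stronger inhibitor. Compound 1 `CCn1c(CNc2ccccc2)nnc1SCc1nc2cc(C(=O)C(C)C)ccc2o1` gives 600 nM in this assay. Compound 2 `CCn1c(CNc2ccccc2)nnc1SCC(=O)Nc1ccc(C(=O)OC)cc1` gives 540 nM. For compound 3 `CCn1c(CNc2ccccc2)nnc1SCC(=O)Nc1ccc(C(=O)NC)cc1` this assay reports only a limit, > 1000 nM. Among the two numbers, compound 1 stands highest, with compound 2 nearest at a gap that lies within the scatter. Within the data shown here, the only step between measured compounds, an at least 1.8-fold higher number from compound 2 to compound 3 (0.26 log units; that floor lies within the scatter), rests on the limit of > 1000 nM in this assay, at which 1 of the 3 values shown sits, and concerns methylamino in place of methoxy on a carbonyl carbon, a site that compound 1 does not carry.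

Compound 4 `CCn1c(CNc2ccccc2)nnc1SCc1nc2cc(OC(F)(F)F)ccc2o1` differs from compound 1 by trifluoromethoxy in place of isopropylcarbonyl on an aromatic carbon. No measured step touches this position or this kind of exchange, so the move from compound 1 to compound 4 has no measured counterpart among the shown compounds. Compound 4 is therefore expected to show a 1.2-fold higher number from compound 1 to compound 4 (0.07 log units; within the scatter), a step that stays within the scatter. The estimate for compound 4 is 700 nM, with an expected range from 250 nM to 2000 nM.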

Compound 4, half-maximal inhibitory concentration: 100 nM
Compound 4: the middle estimate sits 7.0-fold (0.85 log units) above what was measured; the whole stated range lies above it.
By their numbers in this assay, from the lowest: compound 4; then compounds 2 and 1 (each within the scatter of the next). At a limit, above all of these: compound 3.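

Within this assay the exchange of isopropylcarbonyl for trifluoromethoxy on this aromatic carbon gives a 6.0-fold lower number from compound 1 to compound 4 (0.78 log units; beyond the scatter) and is the first step shown that lies beyond the scatter. It shows that this position responds to the group it carries, even though the two groups match in their counts of heavy atoms, hydrogen-bond donors and hydrogen-bond acceptors and differ in their elements and in the double bond that leaves with the carbonyl. Nothing measured here accounts for this step.

On these data alone, whether the lower number goes with the fluorine atoms, the ether oxygen or the loss of the carbonyl stays open, and a methoxy, trifluoromethyl or chlorine group on this carbon would help to separate these. Also open, as far as these compounds go, is how an amine or a carboxylic acid would fare at this position.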